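A few compounds are considered here, and "the series" means these few. Any claim that something is new, unique, unknown or untested is made for them only; others in the source may bear on it.

In an ADME assay on the whole organism (plasma, Rattus norvegicus) for protein binding, using cassette dosing, at a dose of 1 mg/kg (on this read-out lower numbers stand for a smaller free fraction and higher numbers for a larger free fraction), compound 1 (`Cc1ccc(Cn2c(=O)n(CC(C)(C)C(=O)O)c(=O)[nH]/c2=N\c2ccc(OC(C)C)c(Cl)c2)cc1`) gives 0.01, compound 2 (`Cc1ccc(Cn2c(=O)n(C[C@H](C)C(=O)O)c(=O)[nH]/c2=N\c2ccc(OC(C)C)c(Cl)c2)cc1`) gives 0.014 and compound 3 (`C[C@@H](Cn1c(=O)[nH]/c(=N\c2ccc(Oc3ccc(F)cn3)cc2)n(Cc2ccc(Cl)cc2)c1=O)C(=O)O`) gives 0.011. All three numbers lie within the scatter of one another, so compound 3 stands level with the other two. Compound 4 (`C[C@@H](Cn1c(=O)[nH]/c(=N\c2ccc(Oc3ccsn3)cc2)n(Cc2ccc(Cl)cc2)c1=O)C(=O)O`) differs from compound 3 in one place, with 1,2-thiazol-3-yl in place of 5-fluoropyridin-2-yl on an oxygen on an aromatic ring. Within the data shown here, no measured step touches that place. The only one available, a 1.4-fold higher number from compound 1 to compound 2 (0.15 log units; within the scatter), concerns a saturated chain carbon bound to an aromatic nitrogen, so it bears on this change only indirectly. With compound 3 at 0.011 and that one step within the scatter, no step beyond the scatter is expected in this assay, and the data offer no firm direction. The estimated step is a 1.3-fold higher number from compound 3 to compound 4 (0.10 log units; within the scatter). For compound 4 the expected value is 0.014, with an estimated range from 0.007 to 0.03.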

Compound 4, unbound fraction: 0.012
For compound 4 the middle estimate is 1.2-fold (0.07 log units) above the measured one; the measured number falls inside the stated range.
By their numbers in this assay, from the lowest: compounds 1, 3, 4 and 2 (each within the scatter of the next).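

In this assay, 1,2-thiazol-3-yl in place of 5-fluoropyridin-2-yl on an oxygen on an aromatic ring gives a 1.1-fold higher number from compound 3 to compound 4 (0.04 log units; within the scatter). Among these compounds, this is the first step read at this place, and it shows that a five-membered aromatic ring with two hetero atoms and a six-membered aromatic ring with one hetero atom stand level in this pair, despite their different heavy-atom counts. No measurement at hand explains this level reading.

The compounds shown leave open whether a group of another kind on that oxygen, such as a chain ending in an amine or a carboxylic acid, would give a step beyond the scatter. Among the compounds shown here, with only one pair at this place, they also leave open whether the level reading would hold with other groups elsewhere on the shared core.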